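The source may report more compounds than this note shows. Statements on the series, on what has been measured and on what is new or still open speak of the compounds shown alone.

Values measured so far in an ADME assay on MRC5 cells (Homo sapiens) for cytotoxicity, read by resazurin assay, with a stated time of 72 h (a higher number here means a weaker inhibitor, a lower number a stronger inhibitor), each one a limit and not a number:
- compound 1 `O=[N+]([O-])c1cn2c(n1)OC(COc1ccc(-c3ccc(F)nc3F)nc1)CC2` gives > 64000 nM as a limit
- compound 2 `O=[N+]([O-])c1cn2c(n1)OC(COc1ccc(-c3ccc(F)cc3)nn1)CC2` gives > 64000 nM as a limit
- compound 3 `CC1(COc2ccc(-c3ccc(F)nc3F)nc2)CCn2cc([N+](=O)[O-])nc2O1` gives > 64000 nM as a limit

Compound 3 therefore stands only at a limit, and the other two values are limits as well. The whole set reads the limit of > 64000 nM in this assay, at which 3 of the 3 values shown sit, and offers no number to work from.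

The next step leads to compound 4 `CC1(COc2ccc(-c3ccc(F)cc3F)nc2)CCn2cc([N+](=O)[O-])nc2O1` and is 2,4-difluorophenyl in place of 2,6-difluoropyridin-3-yl on an aromatic carbon in short, 2,4-difluorophenyl in place of 2,6-difluoropyridin-3-yl on an aromatic carbon.

For the measured compounds named here, the only measured step, a step that the two limits leave unreadable from compound 1 to compound 3, gives no size and concerns a methyl in place of hydrogen on a saturated ring carbon, so it does not address this change. Compound 2 also carries a fluorine-bearing aromatic ring of carbon only, and its limit of > 64000 nM is the nearest guide.

No step beyond the usual scatter is expected in this assay on this basis. The estimated step is an at least 1.0-fold lower number from compound 3 to compound 4 (0.02 log units; that floor lies within the scatter) in size. For compound 4 the expected value is 60000 nM with an estimated range of 30000 nM to 64000 nM and a good chance of another limit.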

Compound 4, half-maximal inhibitory concentration: > 64000 nM
Compound 4: a limit, no number; the forecaster's own chance of this, stated with the estimate: 75%; middle value at least 1.0-fold (0.02 log units) from the limit.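

Compound 3 and compound 4 both stand only as limits in this assay, so no step can be read between them, and the series offers a single reading: the limit of > 64000 nM in this assay, at which 4 of the 4 values shown sit. The compounds shown leave open whether any structural change among them alters the result at all.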